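Swapping an Ether for a Ketone on the Shared Core

The compounds below may be only part of what the source reports. "The series", "measured", "known", "first", "only" and "open" are said of these compounds alone.

Of the compounds shown here, three built on one core have been tested in a functional assay on CHO cells for agonist activity at Alpha-2B adrenergic receptor (Homo sapiens); on this read-out higher numbers stand for an effect only at larger amounts of compound and lower numbers for an effect already at smaller amounts. Compound 1 `C=C(C)c1ccccc1OC(C)C1=NCCN1` gives 1580 nM. Compound 2 `CC(C)Oc1ccccc1OC(C)C1=NCCN1` gives 1740 nM; among the three numbers it stands second highest, separated from compound 1 by a 1.1-fold higher number from compound 1 to compound 2 (0.04 log units; within the scatter) and from compound 3 `COc1ccccc1OC(C)C1=NCCN1`, which gives 100000 nM, by a 57-fold higher number from compound 2 to compound 3 (1.76 log units; beyond the scatter). The gap between compound 1 and compound 3 is similarly large, a 63-fold higher number from compound 1 to compound 3 (1.80 log units; beyond the scatter).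

Compound 4 `CC(=O)c1ccccc1OC(C)C1=NCCN1` awaits measurement. It arises from compound 2 through one change: acetyl in place of isopropoxy on an aromatic carbon. Among the measured compounds shown here, no measured step matches this swap exactly. The nearest guides are the exchange between compound 1 and compound 2, a 1.1-fold higher number from compound 1 to compound 2 (0.04 log units; within the scatter), where two groups of similar bulk gave much the same number, and the shrink to methoxy, a 57-fold higher number from compound 2 to compound 3 (1.76 log units; beyond the scatter), where a much smaller group cost a great deal. Acetyl is smaller than isopropoxy yet larger than methoxy, so compound 4 is expected to land between those outcomes, with a modest loss more likely than a gain. Compound 4 is estimated at 5000 nM, within 1200 nM to 30000 nM. That corresponds to an expected 2.9-fold higher number from compound 2 to compound 4 (0.46 log units; beyond the scatter).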

Compound 4, half-maximal effective concentration: 295 nM
Beside the measured number, compound 4's estimate is 17-fold (1.23 log units) above it, outside the stated range (below it).
By their numbers in this assay, from the lowest: compound 4; then compounds 1 and 2 (each within the scatter of the next); then compound 3.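

At this aromatic carbon, compounds 2 and 3 suggested that a smaller group brings a higher number in this assay, yet acetyl, with fewer heavy atoms than isopropoxy, goes against that pattern with a 5.9-fold lower number from compound 2 to compound 4 (0.77 log units; beyond the scatter) in this step. Acetyl also goes lower than the other two groups, with a 5.4-fold lower number from compound 1 to compound 4 (0.73 log units; beyond the scatter) when it replaces 1-methylethenyl and a 340-fold lower number from compound 3 to compound 4 (2.53 log units; beyond the scatter) when it replaces methoxy. Heavy-atom count alone therefore does not order this position, and a double bond outside the aromatic ring is not enough by itself, since compound 1 also carries one yet stays level with compound 2.

Nothing available explains why acetyl gives the lowest number of the series. As far as these compounds go, whether a longer ketone such as propanoyl, an amide or a carboxylic acid would follow acetyl at this carbon remains open.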